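Series notes: aryloxy substituent swap and cytotoxicity

A few compounds are considered here, and "the series" means these few. Any claim that something is new, unique, unknown or untested is made for them only; others in the source may bear on it.

Measured so far:
- compound 1 `O=[N+]([O-])c1ccc(NC(=S)NCCNS(=O)(=O)c2ccc(-c3ccccc3O[C@H]3CC[C@@H](O)CC3)s2)cc1`: 20000 nM
- compound 2 `O=C(NCCNS(=O)(=O)c1ccc(-c2ccccc2O[C@H]2CC[C@H](O)CC2)s1)Nc1cc(Cl)cc(Cl)c1`: > 50000 nM
- compound 3 `O=[N+]([O-])c1ccc(NC(=S)NCCNS(=O)(=O)c2ccc(-c3ccccc3OCc3ccccc3)s2)cc1`: 8900 nM

In an ADME assay on HEK-293T cells (Homo sapiens) for cytotoxicity, read by CCK-8 assay, with a stated time of 48 h (on this read-out higher numbers stand for weaker inhibition and lower numbers for stronger inhibition), compound 3 gives 8900 nM, the lowest of the two numbers seen, with compound 1 nearest at 20000 nM. Compound 2 shows only a limit of the assay, > 50000 nM, and no number (the limit of > 50000 nM in this assay, at which 1 of the 3 values shown sits).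

Compound 4 `O=[N+]([O-])c1ccc(NC(=S)NCCNS(=O)(=O)c2ccc(-c3ccccc3O[C@H]3CC[C@H](O)CC3)s2)cc1` is not yet measured. It differs from compound 3 in one place: 4-hydroxycyclohexyl in place of benzyl on an oxygen on an aromatic ring.

Among the measured compounds shown here, the one measured step that bears on this change is the same swap in the opposite direction, a 2.2-fold lower number from compound 1 to compound 3 (0.35 log units; beyond the scatter), a modest step beyond the scatter. Reversing it, compound 4 is expected to sit at a modestly higher number than compound 3 in this assay, and the expected step is a 2.2-fold higher number from compound 3 to compound 4 (0.35 log units; beyond the scatter). Compound 4 is therefore estimated at 20000 nM, with a range from 9000 nM to 45000 nM, pending the measurement.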

Compound 4, half-maximal inhibitory concentration: 10500 nM
Compound 4: the middle estimate sits 1.9-fold (0.28 log units) above what was measured, within the range that was stated.
By their numbers in this assay, from the lowest: compounds 3, 4 and 1 (each within the scatter of the next, the first and the last beyond it). At a limit, above all of these: compound 2.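

In this assay, the swap of benzyl for 4-hydroxycyclohexyl on the oxygen now gives a 1.2-fold higher number from compound 3 to compound 4 (0.07 log units; within the scatter), so this change does not always register, although a 2.2-fold lower number from compound 1 to compound 3 (0.35 log units; beyond the scatter) lay beyond the scatter. The two 4-hydroxycyclohexyl forms also stay close, with a 1.9-fold lower number from compound 1 to compound 4 (0.28 log units; within the scatter), so the configuration as drawn gives no difference that can be read here, and the earlier step depends on which form is compared, a reading that rests on this: the fact that compounds 1 and 4 differ only in the configuration as drawn. Among the compounds shown here, the group on the amine nitrogen gives the one larger step, an at least 4.7-fold lower number from compound 2 to compound 4 (0.67 log units; beyond the scatter), which is bounded only, since the value of compound 2 is a limit of the assay.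

As far as these compounds go, whether other groups on this oxygen, such as an amine-bearing cyclohexyl or a longer chain, would stay within the same band remains open. Also open, from the compounds shown here alone, is how far the number for compound 2 lies past its limit.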